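The compounds below may be only part of what the source reports. "The series", "measured", "known", "first", "only" and "open" are said of these compounds alone.

Measured compounds:
- compound 1, `O=C(Nc1ccccc1)Nc1cccc(CNc2nccnc2Cl)c1`: 15600 nM
- compound 2, `COc1ccccc1NC(=O)Nc1cccc(CNc2nccnc2Cl)c1`: 13700 nM

Both were tested in a functional assay on HepG2 cells (Homo sapiens) for antiproliferative activity, read by MTT assay, with a stated time of 48 h; a lower number here means a stronger inhibitor, a higher number a weaker inhibitor. Compound 1 gives 15600 nM and compound 2 gives 13700 nM, so compound 1 holds the highest of the two numbers, and its nearest neighbour is compound 2, the two lying within the scatter of each other. Among the compounds with values here, the one step that has been measured, a 1.1-fold lower number from compound 1 to compound 2 (0.06 log units; within the scatter), therefore shows no effect beyond the scatter.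

The unmeasured compound 3, `Cc1ccc(NC(=O)Nc2cccc(CNc3nccnc3Cl)c2)cc1Cl`, differs from compound 1 in one place: 3-chloro-4-methylphenyl in place of phenyl on an amide-type nitrogen. Within the data shown here, the only step that bears on it is the one from compound 1 to compound 2, since that change also sits on the anilino end of the shared core, and it was too small to read. The change to compound 3 is larger, but nothing measured tells which way it will go. Compound 3 is therefore expected to fall near compound 1, with a wide range, and the step of a 1.7-fold lower number from compound 1 to compound 3 (0.24 log units; within the scatter) is the estimate. For compound 3 the expected value in this assay is 9000 nM, between 2500 nM and 25000 nM.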

Compound 3, half-maximal inhibitory concentration: 11300 nM
Estimate against measurement, compound 3: 1.3-fold (0.10 log units) below; low and high end bracket the measured number.
By their numbers in this assay, from the lowest: compounds 3, 2 and 1 (each within the scatter of the next).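

In this assay, putting 3-chloro-4-methylphenyl in place of phenyl on the amide-type nitrogen gives a 1.4-fold lower number from compound 1 to compound 3 (0.14 log units; within the scatter), so a ring carrying chlorine and methyl reads no differently here from the unsubstituted one. Within the data shown here, the exchange between the two substituted rings, a 1.2-fold lower number from compound 2 to compound 3 (0.08 log units; within the scatter), also stays within the scatter, which means that 2-methoxyphenyl and 3-chloro-4-methylphenyl cannot be told apart at this position, something the single methoxy step could not show. Phenyl and both substituted rings on this nitrogen therefore all read alike, and no supporting evidence is available to explain this.

The compounds shown leave open whether any group on this nitrogen can move the number beyond the scatter, for example a pyridine ring, a ring bearing a carboxylic acid or an amine, or a longer alkyl chain in place of the aromatic ring. They also leave open whether the chlorine and the methyl of compound 3 would read the same each on its own, and whether a change in another part of the shared core would have a larger effect.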